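Working notes: from compound 2 to compound 3

This account rests on a few compounds, and the source may have more. Where it says the series, first, only, none or still open, it means among the compounds named here.

Compound 2 `N#C/C(=C\N1CCN(C(=O)c2ccco2)C1=S)C(N)=O` gives 13100 nM in a functional assay on MDA-MB-231 cells (Homo sapiens) for inhibition, read by sulforhodamine B assay, with a stated time of 48 h; on this read-out lower numbers stand for stronger inhibition of growth and higher numbers for weaker inhibition of growth. Going by the values given here, this is the lowest of the two numbers measured so far; the nearest is compound 1 `N#C/C(=C\N1CCN(C(=O)c2ccco2)C1=S)C(=O)Nc1ccc(Cl)cc1`, which gives 18400 nM in this assay, and the step of a 1.4-fold lower number from compound 1 to compound 2 (0.15 log units; within the scatter) is within the scatter. Compound 3 `N#C/C(=C\N1CCN(C(=O)c2ccco2)C1=S)C(=O)c1ccccc1` is not yet measured. It differs from compound 2 in one place: phenyl in place of amino on a carbonyl carbon. Among the compounds with values here, only the step from compound 1 to compound 2 bears on this change, and only loosely, since that step sits on the amide-type nitrogen rather than on the carbonyl carbon; there the departure of an aromatic ring left the number within the scatter. Within the data shown here, with no measured step at the carbonyl carbon itself, the expected step of a 1.1-fold lower number from compound 2 to compound 3 (0.04 log units; within the scatter) is none beyond the scatter. Compound 3 is therefore estimated at 12000 nM in this assay, with a range from 5000 nM to 30000 nM.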

Compound 3, concentration for 50% growth inhibition: 13700 nM
The estimate for compound 3 lay 1.1-fold (0.06 log units) below the measured number, and the stated range covers the measured number.
By their numbers in this assay, from the lowest: compounds 2, 3 and 1 (each within the scatter of the next).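

The carbonyl carbon now has a measured step of its own in this assay: a 1.0-fold higher number from compound 2 to compound 3 (0.02 log units; within the scatter). Phenyl and amino are therefore not told apart at this position, even though the change adds a six-membered aromatic ring and removes the hydrogen-bond donor counted on amino. The comparison with the larger amide-type group gives the same reading, a 1.3-fold lower number from compound 1 to compound 3 (0.13 log units; within the scatter), and nothing on hand bears on why these values lie so close.

Still open, on these data alone, is whether any other group on this carbonyl carbon, such as hydroxyl, methoxy or a butyl chain, would give a step beyond the scatter. Also open, as far as these compounds go, is whether this reading would hold on a different core, since all three compounds share the same one.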